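Isopropyl in Place of Fluoro: Oral Bioavailability Outlook

The compounds below may be only part of what the source reports. "The series", "measured", "known", "first", "only" and "open" are said of these compounds alone.

Measured compounds:
compound 1 `CS(=O)(=O)c1ccc(F)c(C#Cc2cc(Cl)ccc2OCC(=O)O)c1`: 24%
compound 2 `CC(C)c1ccc(S(C)(=O)=O)cc1C#Cc1cc(C#N)ccc1OCC(=O)O`: 26%
compound 3 `CCCS(=O)(=O)c1ccc(C)c(C#Cc2cc(C#N)ccc2OCC(=O)O)c1`: 24%

Three compounds have been run in an in vivo ADME assay on the whole organism (strain BALB/c) for pharmacokinetics, with Mus musculus as the target, read by LC-MS, at a dose of 5 mg/kg by the oral route; on this read-out lower numbers stand for lower oral bioavailability and higher numbers for higher oral bioavailability. Compound 1 gives 24% and compound 3 gives 24%, level at the digits shown, and together they are the lowest of the three numbers. Compound 2 gives 26%, a number within the scatter of compound 1, so nothing can be made of the order among them.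

The piece follows the step from compound 1 to compound 4 `CC(C)c1ccc(S(C)(=O)=O)cc1C#Cc1cc(Cl)ccc1OCC(=O)O`, which has not yet been measured in this assay. The change is isopropyl in place of fluoro on an aromatic carbon. Compound 2 also carries an isopropyl group and gives a number within the scatter of compound 1, so no step beyond the scatter is expected here. Compound 4 is therefore estimated at 25%, with a range from 12% to 40%, which means an expected step of a number 1 percentage points higher from compound 1 to compound 4 (within the scatter).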

Compound 4, oral bioavailability: 29%
Estimate against measurement, compound 4: 4 percentage points below; measured number inside the range.
By their numbers in this assay, from the lowest: compounds 1, 3, 2 and 4 (each within the scatter of the next).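

In this assay the swap of isopropyl in place of fluoro, on the aromatic carbon ortho to a large group and para to a methylsulfonyl group, can now be read directly (a number 5 percentage points higher from compound 1 to compound 4 (within the scatter)), and the larger group leaves oral bioavailability within the usual scatter. With isopropyl held, chloro in place of cyano on an aromatic carbon of the other ring also stays within the scatter (a number 3 percentage points higher from compound 2 to compound 4 (within the scatter)), so neither single change separates these compounds on this read-out. No measurement here bears on why these steps are so small.

On these data alone, it remains open whether an amine or a longer chain on the isopropyl-bearing carbon would move oral bioavailability beyond the scatter. As far as these compounds go, it is equally open whether an amide in place of the carboxylic acid would do so.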